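This account rests on a few compounds, and the source may have more. Where it says the series, first, only, none or still open, it means among the compounds named here.

Of the compounds shown here, two of a shared core have been measured in a functional assay on A549 cells (Homo sapiens) for cytotoxicity, read by MTT assay, with a stated time of 72 h; on this read-out higher numbers stand for weaker inhibition and lower numbers for stronger inhibition. Compound 1, `COc1cc(Nc2nc3ccccc3nc2S(=O)(=O)c2ccccc2)cc(OC)c1`, gives 70 nM in this assay. Compound 2, `COc1ccc(Nc2nc3ccccc3nc2S(=O)(=O)c2ccc(Br)cc2)cc1`, gives 3340 nM in this assay, the highest of the two numbers recorded, with compound 1 standing well beyond the scatter below it. Among the measured compounds shown here, compound 1 and compound 2 differ in more than one place, so no single step between them can be read from these two values.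

Compound 3, `COc1cc(Nc2nc3ccccc3nc2S(=O)(=O)c2ccc(Br)cc2)cc(OC)c1`, has not yet been measured in this assay. It differs from compound 2 in one place: 3,5-dimethoxyphenyl in place of 4-methoxyphenyl on a nitrogen on an aromatic ring. For the measured compounds named here, the group that enters is the one that compound 1 carries on that nitrogen, while the rest of compound 3 matches compound 2.

Since compound 1 gives 70 nM and compound 2 gives 3340 nM in this assay, a step from compound 2 to compound 3 toward a lower number is expected, and its size is taken to be an 11-fold lower number from compound 2 to compound 3 (1.05 log units; beyond the scatter). Compound 3 is therefore expected to give about 300 nM in this assay, with a range from 60 nM to 1500 nM.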

Compound 3, half-maximal inhibitory concentration: 15900 nM
For compound 3 the middle estimate is 53-fold (1.72 log units) below the measured one, outside the stated range (above it).
By their numbers in this assay, from the lowest: compound 1; then compound 2; then compound 3.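

In this assay, among the compounds shown here, 3,5-dimethoxyphenyl on the nitrogen does not lower the number when bromo is present on the aromatic carbon, since the change gives a 4.8-fold higher number from compound 2 to compound 3 (0.68 log units; beyond the scatter), the opposite direction to the one the low value of compound 1 had suggested. The 3,5-dimethoxyphenyl group therefore does not carry a low number on its own, and the bromo-for-hydrogen change matters strongly in this series, with a 230-fold higher number from compound 1 to compound 3 (2.36 log units; beyond the scatter), a large step that places compound 3 highest of the three. No measurement here bears on why either step takes the size it does.

The compounds shown leave open how 4-methoxyphenyl behaves with hydrogen in place of bromo, so it cannot be said whether the preference between the two groups on the nitrogen holds once bromo is gone. They also leave open whether the rise belongs to bromo in particular or would also follow from another group on that aromatic carbon, such as fluoro, methyl or an amine.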